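The source may hold more compounds than are shown below. What is called first, only, known or untested is meant among the compounds shown, and "the series" means these compounds.

Working notes on the sulfonyl-benzyl amide series, followed in an ADME assay on microsomes from liver (Mus musculus) for metabolic stability, read by LC-MS, with a stated time of 30 min, tested at 1 uM; on this read-out lower numbers stand for a less stable compound and higher numbers for a more stable compound.

Compound 1 `O=C(NCc1ccc(S(=O)(=O)c2ccccc2)cc1)c1cc(-c2cccnc2)[nH]n1` gives 42% in this assay. Compound 2 `O=C(NCc1ccc(S(=O)(=O)c2ccccc2)cc1)c1cc2ncccc2s1` gives 1.6% in this assay, a fall from compound 1 that lies well beyond the scatter. Compound 3 `O=C(NCc1ccc(S(=O)(=O)N2CCCCC2)cc1)c1cc2cnccc2s1` is reported in this assay only as "below limit of detection" (no number reported), with no number given. Compound 3 thus stands without a resolved value at the low end of the series; what is known is that nothing was detected after the incubation, so it cannot be placed against compound 2 with any confidence.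

Compound 4 `O=C(NCc1ccc(S(=O)(=O)N2CCCCC2)cc1)c1ccn2cncc2c1` is not yet measured. It differs from compound 3 by a group of 9 heavy atoms (7 carbon, 2 nitrogen; one five-membered aromatic ring with 2 hetero atoms, one six-membered aromatic ring with 1 hetero atom) in place of a group of 9 heavy atoms (7 carbon, 1 nitrogen, 1 sulfur; one five-membered aromatic ring with 1 hetero atom, one six-membered aromatic ring with 1 hetero atom), on a carbonyl carbon. Among the compounds with values here, no measured pair shows this change, so its size is not known from the data. The expectation is a step upward of modest size, probably just beyond the scatter, since compound 2 gives 1.6% and compound 3 gives no number at all, leaving little room below. For compound 4 the remaining fraction in this assay is estimated at 10%, with a range from 1% to 35%.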

Compound 4, percent of the compound remaining: 1%
Estimate against measurement, compound 4: 9 percentage points above; measured number inside the range.
By their numbers in this assay, from the lowest: compounds 4 and 2 (each within the scatter of the next); then compound 1.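

In this assay, within the data shown here, compound 4 gives 1% but compound 3 has no number, so no step between them can be read. The compounds shown leave open how the group entering on the carbonyl carbon compares with the one it replaces. Nothing shown bears on a cause for this result.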